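The source may report more compounds than this note shows. Statements on the series, on what has been measured and on what is new or still open speak of the compounds shown alone.

Of the compounds shown here, three sharing one core have been tested so far. In a functional assay on HeLa cells (Homo sapiens) for cytotoxicity, read by sulforhodamine B assay (on this read-out lower numbers stand for stronger inhibition and higher numbers for weaker inhibition), compound 1 (`CC(C)C(NS(=O)(=O)c1ccc(F)cc1)C1=CC(=O)c2c(O)ccc(O)c2C1=O`) gives 6650 nM, compound 2 (`CC(C)C(NS(=O)(=O)c1ccccc1Br)C1=CC(=O)c2c(O)ccc(O)c2C1=O`) gives 8310 nM, and compound 3 (`CC(NS(=O)(=O)c1ccc(F)cc1)C1=CC(=O)c2c(O)ccc(O)c2C1=O`) gives 6410 nM. Compound 3 therefore stands within the usual scatter of compound 1, and its value and that of compound 2 lie close together too, so these numbers set no clear order among the three.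

The next compound is compound 4 (`CC(NS(=O)(=O)c1ccccc1Br)C1=CC(=O)c2c(O)ccc(O)c2C1=O`), which keeps everything in compound 3 except the aromatic group on the sulfonyl sulfur: 2-bromophenyl in place of 4-fluorophenyl on a sulfonyl sulfur. In words, 2-bromophenyl takes the place of 4-fluorophenyl.

For the measured compounds named here, two measured steps bear on this. The same exchange has been measured once, with isopropyl on the saturated chain carbon rather than methyl, and it gave a 1.2-fold higher number from compound 1 to compound 2 (0.10 log units; within the scatter). The change between those two chain groups gave a 1.0-fold lower number from compound 1 to compound 3 (0.02 log units; within the scatter), so the chain group made no measurable difference in that one pair. Carrying the exchange over to the methyl compounds, the expected change is a 1.2-fold higher number from compound 3 to compound 4 (0.09 log units; within the scatter), which would not exceed the scatter. For compound 4 the estimated value is 7800 nM, with an expected range from 4500 nM to 13000 nM.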

Compound 4, half-maximal inhibitory concentration: 6200 nM
Beside the measured number, compound 4's estimate is 1.3-fold (0.10 log units) above it; low and high end bracket the measured number.
By their numbers in this assay, from the lowest: compounds 4, 3, 1 and 2 (each within the scatter of the next).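

Until now, the exchange of 4-fluorophenyl for 2-bromophenyl on a sulfonyl sulfur had been read only with isopropyl on the saturated chain carbon; with methyl there, this assay shows a 1.0-fold lower number from compound 3 to compound 4 (0.01 log units; within the scatter). The two readings of this exchange agree: the same change on two cores in this assay, a 1.2-fold higher number (0.10 log units; within the scatter) from compound 1 to compound 2 and a 1.0-fold lower number (0.01 log units; within the scatter) from compound 3 to compound 4, 1.3-fold (0.11 log units) apart, within the scatter of two such steps. The change from isopropyl to methyl on the chain carbon now has a second reading as well, a 1.3-fold lower number from compound 2 to compound 4 (0.13 log units; within the scatter), so neither change has moved the number beyond the scatter with either partner group: the same change on two cores in this assay, a 1.0-fold lower number (0.02 log units; within the scatter) from compound 1 to compound 3 and a 1.3-fold lower number (0.13 log units; within the scatter) from compound 2 to compound 4, 1.3-fold (0.11 log units) apart, within the scatter of two such steps.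

Going by these compounds, all four compounds carry a halogen-bearing phenyl group on the sulfonyl sulfur and either methyl or isopropyl on the chain carbon, so it remains open whether an amine or a carboxylic acid on that phenyl ring, a plain alkyl chain in its place, or a longer chain on the chain carbon would shift the number. On these data alone, all these readings also come from a single cell line, so it remains open whether the same flat picture would hold in other cells.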